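Triazole aryl swap on a shared core, cytotoxicity

The source may report more compounds than this note shows. Statements on the series, on what has been measured and on what is new or still open speak of the compounds shown alone.

Compound 1 `C=C1C[C@]23C[C@@]1(O)CC[C@H]2c1ccc(O)c(C)c1[C@@H]3Cn1cc(-c2ccccn2)nn1` carries a pyridin-2-yl group on the triazole. In a functional assay on MCF7 cells (Homo sapiens) for cytotoxicity, read by MTT assay, with a stated time of 4 days (on this read-out lower numbers stand for stronger inhibition and higher numbers for weaker inhibition), compound 1 gives only a limit, > 20000 nM, and not a number. Compound 2 `Cc1c(O)ccc2c1[C@H](Cn1cc(-c3ccccn3)nn1)[C@@]13CC(=O)[C@@](C)(CC[C@@H]21)C3`, which bears the same triazole substituent on a differently built core, also returns only a limit in this assay, namely > 20000 nM. Going by the values given here, both results thus sit at the limit of > 20000 nM in this assay, at which 2 of the 2 values shown sit, so no step between measured compounds can be computed, and compound 1 can be placed on the numbers only as one of two entries that are limits rather than values.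

Compound 3 `C=C1C[C@]23C[C@@]1(O)CC[C@H]2c1ccc(O)c(C)c1[C@@H]3Cn1cc(-c2ccc(Br)cc2)nn1` differs from compound 1 in one place, 4-bromophenyl in place of pyridin-2-yl on an aromatic carbon. Among the compounds with values here, no measured pair speaks to this change. On the material available the expectation for this assay is no step beyond the usual scatter, with a limit again the most likely outcome. Compound 3 is therefore expected near 25000 nM, within 8000 nM to 60000 nM. The step that the limit leaves unreadable from compound 1 to compound 3 that this estimate implies is expected to be essentially none.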

Compound 3, half-maximal inhibitory concentration: > 20000 nM
Compound 3: only a limit was reported; the forecaster's own chance of this, stated with the estimate: 75%; the middle value lies beyond the limit too.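

Compound 1 and compound 3 both return limits and not numbers in this assay, so no step between them can be read: the limit of > 20000 nM in this assay, at which 3 of the 3 values shown sit.

The compounds shown leave open whether 4-bromophenyl in place of pyridin-2-yl changes cytotoxicity at all, and which structures on this core would give a readable number.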